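A few compounds are considered here, and "the series" means these few. Any claim that something is new, unique, unknown or untested is made for them only; others in the source may bear on it.

Series notes, sulfur-linked side chain. For the measured compounds named here, compound 2 `CC(C)c1n[nH]c2c(NCc3ccc(-c4ccccn4)cc3)nc(SCC(N)CN)nc12` gives 480 nM in a functional assay on HT cells (Homo sapiens) for antiproliferative activity, read by fluorescence, with a stated time of 72 h (a lower number here means a stronger inhibitor of growth, a higher number a weaker inhibitor of growth), the lowest of the three numbers so far; compound 1 `CC(C)c1n[nH]c2c(NCc3ccc(-c4ccccn4)cc3)nc(SCC(O)C(F)(F)F)nc12` gives 690 nM and compound 3 `CC(C)c1n[nH]c2c(NCc3ccc(-c4ccccn4)cc3)nc(SC(CO)C(C)C)nc12` gives 980 nM. The step of a 1.4-fold lower number from compound 1 to compound 2 (0.16 log units; within the scatter) and the step of a 1.4-fold higher number from compound 1 to compound 3 (0.15 log units; within the scatter) both lie within the scatter, while the step of a 2.0-fold higher number from compound 2 to compound 3 (0.31 log units; beyond the scatter) is the only one beyond it. Compound 4 `CC(=O)NCCSc1nc(NCc2ccc(-c3ccccn3)cc2)c2[nH]nc(C(C)C)c2n1` carries acetamidomethyl in place of 1,2-diaminoethyl on a saturated chain carbon bound to a sulfur. The three measured side-chain swaps on the sulfur-bound chain bear on this change, and they move the number over a narrow span, with compound 2 at one end and compound 3 at the other. The same kind of step is therefore expected here: at most a modest rise from compound 2, as with compound 3, or no step beyond the scatter, as with compound 1. Compound 4 is expected at 750 nM, within 350 nM to 1600 nM, a step of a 1.6-fold higher number from compound 2 to compound 4 (0.19 log units; within the scatter).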

Compound 4, concentration for 50% growth inhibition: 71 nM
Beside the measured number, compound 4's estimate is 11-fold (1.02 log units) above it; measured number outside the range, below it.
By their numbers in this assay, from the lowest: compound 4; then compounds 2, 1 and 3 (each within the scatter of the next, the first and the last beyond it).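

Working notes on the sulfur-bound chain: this position is more sensitive than the three earlier chains indicated, since in this assay the 2-acetamidoethyl chain of compound 4 separates clearly from each of them. The change from the earlier chains gives a 6.8-fold lower number from compound 2 to compound 4 (0.83 log units; beyond the scatter) and a 9.7-fold lower number from compound 1 to compound 4 (0.99 log units; beyond the scatter) and a 14-fold lower number from compound 3 to compound 4 (1.14 log units; beyond the scatter) in that assay. Among the chains shown, only the one in compound 4 carries an amide carbonyl and has no branch on the chain, so the lowest number goes with a chain unlike the others in both respects.

Which of these two features matters stays open, and a longer chain between sulfur and amide, a methanesulfonamide or a branched acetamide chain would separate them. Nothing in the data shown gives a reason for these steps.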